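This account rests on a few compounds, and the source may have more. Where it says the series, first, only, none or still open, it means among the compounds named here.

Measured so far:
- compound 1, `COc1cc(OC)cc(N2NC3=CC[C@@H](OC)O[C@@]3(c3ccncc3)CC2=O)c1`: 6400 nM
- compound 2, `COc1ccc(N2NC3=CC[C@@H](OC)O[C@@]3(c3ccccc3)CC2=O)cc1`: 10400 nM

In a functional assay on SK-N-SH cells (Homo sapiens) for inhibition, read by sulforhodamine B assay, with a stated time of 48 h (a higher number here means a weaker inhibitor, a lower number a stronger inhibitor), compound 1 gives 6400 nM, and compound 2 gives 10400 nM; the gap between these two numbers lies within the usual scatter of repeated measurements, so neither can be called the stronger inhibitor on this evidence. Compound 3, `COc1cc(OC)cc(N2NC3=CC[C@@H](OC)O[C@@]3(C)CC2=O)c1`, has not yet been measured. It keeps the shared core of compound 1 and differs in one place: methyl in place of pyridin-4-yl on a saturated ring carbon. Among the compounds with values here, no measured pair in this set shows such a change, so the expected size of the step rests on the structural change alone. A single carbon taking the place of an aromatic ring removes a sizeable part of the molecule, and the expectation is that the number rises, meaning a weaker inhibitor, by a step of a 2.5-fold higher number from compound 1 to compound 3 (0.40 log units; beyond the scatter) beyond the scatter. Compound 3 is estimated at 16000 nM in this assay, within a range of 5000 nM to 50000 nM.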

Compound 3, half-maximal inhibitory concentration: 23700 nM
Compound 3: the middle estimate sits 1.5-fold (0.17 log units) below what was measured; the range from low to high includes it.
By their numbers in this assay, from the lowest: compounds 1 and 2 (each within the scatter of the next); then compound 3.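

In this assay, putting methyl in place of pyridin-4-yl on this saturated ring carbon gives a 3.7-fold higher number from compound 1 to compound 3 (0.57 log units; beyond the scatter) and so makes compound 3 the weaker inhibitor. Within the data shown here, this is the first readable evidence that the group on this carbon affects the number, which the earlier pair could not show because its values lie within the scatter. The step is modest, though: with a six-membered aromatic ring replaced by a single carbon, compound 3 still gives a measured number, and nothing available says why the number rises.

Still open, as far as these compounds go, is whether ethyl, a longer chain or a phenyl ring on this carbon, with the rest of compound 1 kept, would land nearer compound 1 or compound 3. Also open, from the compounds shown here alone, is how a group bearing an amine or a carboxylic acid would behave here.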